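Trimming the sulfonyl chain of an indole carboxamide

A few compounds are considered here, and "the series" means these few. Any claim that something is new, unique, unknown or untested is made for them only; others in the source may bear on it.

Compound 1 `NC(=O)c1cc(-c2ccccc2)cc2c(C3CCN(S(=O)(=O)CCCN4CCCC4)CC3)c[nH]c12` was examined in an ADME assay on the whole organism (Rattus norvegicus, strain Sprague-Dawley) for pharmacokinetics, at a dose of 2 mg/kg by the oral route (on this read-out higher numbers stand for higher oral bioavailability and lower numbers for lower oral bioavailability), where compound 1 gives 12%. Within the data shown here, compound 2 `NC(=O)c1cc(-c2ccc(F)cc2)cc2c(C3CCS(=O)(=O)CC3)c[nH]c12` is the only other compound with a number in this assay, and in this assay compound 2 gives 47.4%. Among the measured compounds shown here, on these two numbers compound 1 stands lowest, with compound 2 a step higher that lies beyond the scatter; no single-point step between measured compounds is known.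

Compound 3 `CCS(=O)(=O)N1CCC(c2c[nH]c3c(C(N)=O)cc(-c4ccccc4)cc23)CC1` has not yet been measured in this assay. It differs from compound 1 in one place: hydrogen in place of (pyrrolidin-1-yl)methyl on a saturated chain carbon, two bonds along the chain from a sulfonyl sulfur

For the measured compounds named here, no measured pair shows this change directly. The author expects the step from compound 1 to compound 3 in this assay to be upward and to exceed the scatter, with a number 23 percentage points higher from compound 1 to compound 3 (beyond the scatter) as the estimated size, because compound 1 gives 12% and thus starts at the low end of what the assay has shown. For compound 3 the author estimates 35%, with a range from 15% to 60%.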

Compound 3, oral bioavailability: 58%
The estimate for compound 3 lay 23 percentage points below the measured number, within the range that was stated.
By their numbers in this assay, from the lowest: compound 1; then compound 2; then compound 3.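

Among these compounds, the change from (3-(pyrrolidin-1-yl)propyl)sulfonyl to ethylsulfonyl brings a number 46 percentage points higher from compound 1 to compound 3 (beyond the scatter) in this assay and is the first single-point step known at this position. Compounds 1 and 2 differ in more than one place, so their numbers could not tie any difference to the sulfonyl chain, whereas this pair isolates that chain on an otherwise unchanged core. The step shows that oral bioavailability in the rat is highly sensitive to this one change, with the shorter chain giving the higher number in this pair, but no measurement here explains why.

From the compounds shown here alone, the two compounds mark only the ends of this change, so it remains open whether the step follows from losing the pyrrolidine ring or from shortening the chain, a question that a plain propyl chain or a 3-(dimethylamino)propyl chain on the sulfonyl could help to separate. Going by these compounds, it is also open how a morpholine ring or a carboxylic acid at the end of the chain would compare, and whether the same step would appear with other groups elsewhere on the core.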